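The source may hold more compounds than are shown below. What is called first, only, known or untested is meant among the compounds shown, and "the series" means these compounds.

In an ADME assay on Vero cells (Chlorocebus sabaeus) for cytotoxicity, read by MTT assay, with a stated time of 72 h (on this read-out higher numbers stand for lower toxicity in this test and lower numbers for higher toxicity in this test), three close analogues share one core and differ only in the aryl group on a saturated chain carbon bound to an amine nitrogen and a saturated chain carbon. Compound 1 `N/C(=N/NC(CC(=O)c1ccc(-n2ccnc2)cc1)c1ccc(Cl)cc1Cl)c1ccccn1` gives 27800 nM. Compound 2 `N/C(=N/NC(CC(=O)c1ccc(-n2ccnc2)cc1)c1cccc(Br)c1)c1ccccn1` gives 51300 nM. Compound 3 `N/C(=N/NC(CC(=O)c1ccc(-n2ccnc2)cc1)c1cccc([N+](=O)[O-])c1)c1ccccn1` gives 28700 nM, which is the second highest of the three numbers, though its neighbours lie within the scatter: a 1.0-fold higher number from compound 1 to compound 3 (0.01 log units; within the scatter), and a 1.8-fold lower number from compound 2 to compound 3 (0.25 log units; within the scatter). The remaining pair also stayed flat: a 1.8-fold higher number from compound 1 to compound 2 (0.27 log units; within the scatter). Compound 4 `N/C(=N/NC(CC(=O)c1ccc(-n2ccnc2)cc1)c1ccc(Cl)cc1)c1ccccn1` has not yet been measured and carries the change (4-chlorophenyl in place of 3-nitrophenyl on a saturated chain carbon bound to an amine nitrogen and a saturated chain carbon). Every aryl swap seen so far at this position, whether a whole ring or a single substituent, left the number within the scatter, so no movement beyond it is expected for compound 4 in this assay. The estimated step for compound 4 is a 1.1-fold higher number from compound 3 to compound 4 (0.05 log units; within the scatter). Compound 4 is expected to give about 32000 nM in this assay. For compound 4 the estimate ranges from 15000 nM to 65000 nM.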

Compound 4, half-maximal cytotoxic concentration: 78800 nM
For compound 4 the middle estimate is 2.5-fold (0.39 log units) below the measured one, outside the stated range (above it).
By their numbers in this assay, from the lowest: compounds 1, 3, 2 and 4 (each within the scatter of the next, the first and the last beyond it).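

In this assay, this position now gives steps beyond the scatter, though modest ones: a 2.7-fold higher number from compound 3 to compound 4 (0.44 log units; beyond the scatter), with 4-chlorophenyl replacing 3-nitrophenyl, and a 2.8-fold higher number from compound 1 to compound 4 (0.45 log units; beyond the scatter), where a hydrogen replaces one chloro on the aromatic ring. The second step is the more telling, as a single-atom change on the ring is enough to separate the two compounds, which no earlier comparison had done. Compound 2 keeps the picture from being a simple ladder, however: a 1.5-fold higher number from compound 2 to compound 4 (0.19 log units; within the scatter) stays within the scatter, so 3-bromophenyl and 4-chlorophenyl cannot be told apart here.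

Nothing available explains why the number moved with these changes. Also open, from the compounds shown here alone, is how this test would read with a plain phenyl at this position, or with an amine or a carboxylic acid on the ring.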